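From Sulfamoyl to Aminopyrimidine at a Solubility Limit

A few compounds are considered here, and "the series" means these few. Any claim that something is new, unique, unknown or untested is made for them only; others in the source may bear on it.

How much of a compound dissolves in water can decide whether it is of any practical use, and a physicochemical assay for solubility, using the shake flask method, in phosphate buffer, with a stated time of 24 h, at pH 7.2 (on this read-out lower numbers stand for lower solubility and higher numbers for higher solubility), puts a figure on that. Here compound 1 (`Cn1c(C(N)=O)cc2cc(NC(=O)C(C)(C)NC(=O)c3ccc4c(C5CCCCC5)c(-c5ccccn5)n(C)c4c3)ccc21`) gives < 0.1 ug/mL as a limit of the assay and not a number. Compound 2 (`Cn1c(-c2ccccn2)c(C2CCCCC2)c2ccc(C(=O)NC3(C(=O)Nc4ccc(S(N)(=O)=O)cc4)CCC3)cc21`) gives < 0.1 ug/mL as a limit too, so it has no exact value. The two measured compounds therefore stand together (the limit of < 0.1 ug/mL in this assay, at which 2 of the 2 values shown sit).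

Compound 3 (`Cn1c(-c2ccccn2)c(C2CCCCC2)c2ccc(C(=O)NC3(C(=O)Nc4ccc(-c5cnc(N)nc5)cc4)CCC3)cc21`) keeps the rest of compound 2 and changes one group: 2-aminopyrimidin-5-yl in place of sulfamoyl on an aromatic carbon, para to a large group (2-aminopyrimidin-5-yl in place of sulfamoyl on an aromatic carbon).

For the measured compounds named here, no measured step shows what such a swap does, so no step beyond the usual scatter is expected in this assay, and the estimated step is small (a step that the limit leaves unreadable from compound 2 to compound 3). This expectation rests on compound 2 with < 0.1 ug/mL as its limit. For compound 3 the estimated value is 0.07 ug/mL with an expected range from 0.02 ug/mL to 0.25 ug/mL and a good chance that the assay again reports only a limit.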

Compound 3, solubility: 0.9 ug/mL
Compound 3: the middle estimate sits 13-fold (1.11 log units) below what was measured; the whole stated range lies below it.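

In this assay, putting 2-aminopyrimidin-5-yl in place of sulfamoyl on an aromatic carbon, para to a large group, gives an at least 9.0-fold higher number from compound 2 to compound 3 (0.95 log units; beyond the scatter). With the rest of compound 2 kept as it is, this single change yields the only exact number among the three compounds shown, so this position is one where the choice of group can move the read-out clear of the scatter. Compound 2 stands at a limit of the assay and not at a number, so the step is a lower bound and its full size stays unknown: the limit of < 0.1 ug/mL in this assay, at which 2 of the 3 values shown sit.

The compounds shown leave open which part of the entering group goes with the higher number: the six-membered aromatic ring with its two nitrogens, or the amine on it, which a plain pyrimidine or an aminophenyl group in the same place would separate. For the compounds shown here, it also remains open how a carboxylic acid or a morpholine would read at this position, and whether the same swap gives a similar step on another core, as this is the only such pair at hand.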